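The source may hold more compounds than are shown below. What is called first, only, known or untested is meant among the compounds shown, and "the series" means these compounds.

Measured so far:
compound 1, `COc1ccccc1N1CCN(CCCOc2ccccc2C(=O)N(C)C)CC1`: 31.6 nM
compound 2, `CN(C)C(=O)c1cccnc1NCCCN1CCN(c2ccccc2OCC2CC2)CC1`: 10 nM

Both numbers come from a functional assay on aorta for antagonist activity at Alpha-1D adrenergic receptor (Rattus norvegicus); on this read-out higher numbers stand for weaker binding and lower numbers for tighter binding. Compound 2 has the lowest number of the two; compound 1 stands higher, and the gap between them lies beyond the scatter. Going by the values given here, no pair of measured compounds differs in a single place, so no measured step can be read as the effect of one change alone.

Compound 3, `CC(C)c1ccccc1N1CCN(CCCNc2ncccc2C(=O)N(C)C)CC1`, has not yet been measured in this assay. It differs from compound 2 in one place: isopropyl in place of cyclopropylmethoxy on an aromatic carbon. The entering group sits on an aromatic carbon of a six-membered aromatic ring of carbon only, ortho to a large group. Among the compounds with values here, nothing among the measured compounds isolates this exchange, since compound 1 and compound 2 differ in several places at once. A modest step toward higher numbers is expected, near the edge of the scatter, as a 2.0-fold higher number from compound 2 to compound 3 (0.30 log units; within the scatter). Compound 3 is expected to give about 20 nM in this assay, with a range from 5 nM to 80 nM.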

Compound 3, dissociation constant: 63.1 nM
Estimate against measurement, compound 3: 3.2-fold (0.50 log units) below, within the range that was stated.
By their numbers in this assay, from the lowest: compound 2; then compounds 1 and 3 (each within the scatter of the next).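

In this assay, going by these compounds alone, isopropyl in place of cyclopropylmethoxy on an aromatic carbon, ortho to a large group, gives a 6.3-fold higher number from compound 2 to compound 3 (0.80 log units; beyond the scatter); this is the first measured exchange that differs in one place only, and it shows that the number at this position responds to the group it carries. The step is a single reading of several differences at once: the leaving group brings 5 heavy atoms, one oxygen, one hydrogen-bond acceptor and a three-membered ring, while the entering isopropyl brings 3 heavy atoms, no acceptor and no ring. No supporting measurement bears on the reason for the step, so it stands here as an observation only.

The compounds shown leave open whether the step follows the oxygen, the three-membered ring or the size of the group, a question that an ethoxy or a cyclopropyl group in the same place could help to separate. Also open, as far as these compounds go, is whether the same exchange would give a similar step on the core of compound 1, as a single pair supports no pattern beyond compound 2 and compound 3.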